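A few compounds are considered here, and "the series" means these few. Any claim that something is new, unique, unknown or untested is made for them only; others in the source may bear on it.

Measured compounds in an ADME assay on WI-38 cells (Homo sapiens) for cytotoxicity, read by MTT assay, with a stated time of 48 h; on this read-out lower numbers stand for stronger inhibition and higher numbers for weaker inhibition:

compound 1, `Cc1ccc(NC(=S)OCCNC(=O)C(C)(C)Oc2ccc(Cl)cc2)cc1`: > 800000 nM
compound 2, `COc1ccc(NC(=S)OCCNC(=O)c2cccnc2)cc1`: 781000 nM
compound 3, `CC(C)(Oc1ccc(Cl)cc1)C(=O)OCCCOC(=O)CCCCC1CCSS1`: > 800000 nM

Compound 1 reports a limit of this assay rather than a number, so its cytotoxicity is only known to lie beyond the tested range. Compound 3 likewise reports a limit. Within the data shown here, compound 2 is the one compound with a numerical half-maximal inhibitory concentration, and that number sits close to the edge of what the assay resolves. Two of the three values sit at the limit of > 800000 nM in this assay, at which 2 of the 3 values shown sit. Among the measured compounds shown here, no pair of measured compounds differs in a single place, so no measured step is available, and compound 1 stands simply among the compounds that show no resolved cytotoxicity.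

Compound 4, `CC(C)(Oc1ccc(Cl)cc1)C(=O)NCCOC(=S)Nc1ccc(F)cc1`, is the next compound for this assay. Relative to compound 1 the change is fluoro in place of methyl on an aromatic carbon. The change is small in size, exchanges one single heavy atom for another on the same aromatic carbon, and touches nothing of the rest of the shared core. For the measured compounds named here, with no measured step to guide it, the expected step is a number no higher from compound 1 to compound 4 (the limit leaves the size open), that is, none beyond the usual scatter. Compound 4 is therefore expected to give 800000 nM in this assay, with a range of 400000 nM to 1600000 nM, and most likely again only a limit.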

Compound 4, half-maximal inhibitory concentration: > 800000 nM
Compound 4: a limit, no number; the forecaster's own chance of this, stated with the estimate: 75%; the middle value sits exactly at the limit.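

In this assay compound 4 gives > 800000 nM, which is a limit and not a number. Compound 1 also stands at a limit, so no step between compound 1 and compound 4 can be read: the limit of > 800000 nM in this assay, at which 3 of the 4 values shown sit.

The compounds shown leave open whether fluoro in place of methyl on an aromatic carbon changes cytotoxicity at all.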